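Thiol Core: Propyl in Place of Isopropyl

The source may hold more compounds than are shown below. What is called first, only, known or untested is meant among the compounds shown, and "the series" means these compounds.

Of the compounds shown here, two on a shared core have been measured so far. Compound 1 `CCCc1nc(C)c2cnnc(O)n12` carries a hydroxy group and a propyl chain; in a functional assay for inhibition, with Homo sapiens as the target (a higher number here means a weaker inhibitor, a lower number a stronger inhibitor), compound 1 gives 56800 nM. Compound 2 `Cc1nc(C(C)C)n2c(S)nncc12` carries a thiol group and an isopropyl chain. For compound 2 in this assay only a limit is recorded, > 48000 nM, so compound 2 stands at the limit of > 48000 nM in this assay, at which 1 of the 2 values shown sits, and no number is known for it. Compound 3 `CCCc1nc(C)c2cnnc(S)n12` is the not yet measured member of the set, and it differs from compound 2 in one place only: propyl in place of isopropyl on an aromatic carbon. Going by the values given here, since no step between measured compounds that differ in one place exists, the size of this change can only be guessed. Both measured compounds sit at weak inhibition, so compound 3 is expected to remain weak and the step that the limit leaves unreadable from compound 2 to compound 3 is expected to be small, with no direction beyond the scatter. For compound 3 in this assay the estimate is 60000 nM, with a range from 20000 nM to 200000 nM, and a limit rather than a number is quite likely to be reported.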

Compound 3, half-maximal inhibitory concentration: 10000 nM
Beside the measured number, compound 3's estimate is 6.0-fold (0.78 log units) above it; measured number below the stated range.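

In this assay, propyl in place of isopropyl gives an at least 4.8-fold lower number from compound 2 to compound 3 (0.68 log units; beyond the scatter), so this position on an aromatic carbon, between two ring nitrogen atoms, responds to how a chain of the same heavy-atom count is joined, and the two chains are not interchangeable here. Going by these compounds alone, compound 2 has only a limit, so this step has a lower bound and its full size remains unknown: the limit of > 48000 nM in this assay, at which 1 of the 3 values shown sits. Sulfanyl in place of hydroxy on an aromatic carbon, with the propyl chain kept, gives a 5.7-fold lower number from compound 1 to compound 3 (0.75 log units; beyond the scatter), which is the first step on the shared core with a number at both ends and shows that the change at this second place also moves the result beyond the scatter.

The compounds shown leave open whether a longer chain such as butyl, or an amine on the same aromatic carbon, would lower the number further or raise it again. They also do not tell whether the step from hydroxy to sulfanyl would have a similar size with isopropyl in place of propyl, or what lies behind either step.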